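Bromo for tert-butyl on the urea aryl ring

The source may report more compounds than this note shows. Statements on the series, on what has been measured and on what is new or still open speak of the compounds shown alone.

The series shares an aryl urea core carrying a methyl-substituted benzylic amine. Compound 1 `C[C@@H](NC(=O)Nc1ccccc1C(C)(C)C)c1ccccc1` gives 17% in an ADME assay on the whole organism with Oryza sativa as the target, tested at 10 uM; a lower number here means a stronger effect, a higher number a weaker effect of the compound at the concentration tested. Within the data shown here, compound 2 `C[C@H](NC(=O)Nc1ccccc1C(C)(C)C)c1ccccc1` gives 100% in this assay, the highest of the three numbers so far; compound 3 `CCCCc1ccc(NC(=O)N[C@H](C)c2ccccc2)cc1` gives 28% in this assay. Compound 2 stands above both: its nearest neighbour on the numbers is compound 3 and its furthest is compound 1. Among the measured compounds shown here, the single measured step, a number 83 percentage points higher from compound 1 to compound 2 (beyond the scatter), rests on the fact that compounds 1 and 2 differ only in the configuration as drawn alone; the numbers of compound 2 and compound 3 come from structures that differ in more than one place, so they show only that both lie far apart.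

Compound 4 `C[C@H](NC(=O)Nc1ccccc1Br)c1ccccc1` differs from compound 2 by bromo in place of tert-butyl on an aromatic carbon, placed on an aromatic carbon of a six-membered aromatic ring of carbon only, ortho to a large group. For the measured compounds named here, no measured step touches this kind of change, so nothing here sets its size or direction. The configuration at the saturated chain carbon is kept from compound 2. Compound 4 is therefore expected to stay nearer compound 2 than compound 1, with a step of a number 30 percentage points lower from compound 2 to compound 4 (beyond the scatter) as the best guess. The estimate for compound 4 in this assay is 70%, within 35% to 100%.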

Compound 4, a percentage reported as activity, at one concentration (the size of the read-out at that concentration, not a potency): 102%
For compound 4 the middle estimate is 32 percentage points below the measured one; measured number above the stated range.
By their numbers in this assay, from the lowest: compound 1; then compound 3; then compounds 2 and 4 (each within the scatter of the next).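

In this assay, bromo in place of tert-butyl on this aromatic carbon, ortho to a large group, gives a pair that cannot be told apart: a number 2 percentage points higher from compound 2 to compound 4 (within the scatter). Among these compounds, with the configuration of compound 2 kept, the exchange of a group of 4 heavy atoms for a group of 1 heavy atom therefore leaves no readable mark at this position, which no earlier pair could show. The only step beyond the scatter among compounds that differ in one place remains a number 83 percentage points higher from compound 1 to compound 2 (beyond the scatter), and so the configuration at the saturated chain carbon is still the one feature seen to matter, a reading that rests on this: the fact that compounds 1 and 2 differ only in the configuration as drawn

Whether bromo and tert-butyl would also match in the other configuration stays open, since the low number of compound 1 belongs to tert-butyl alone among the compounds shown. Also open, on these data alone, is whether this aromatic carbon would tolerate a quite different group, such as an amine or a carboxylic acid, as it tolerates bromo, and how far the butyl chain of compound 3 relates to either group.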